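The source may hold more compounds than are shown below. What is called first, only, known or untested is meant among the compounds shown, and "the series" means these compounds.

Of the compounds shown here, two built on a shared core have been tested in a functional assay on A549 cells (Homo sapiens) for antiproliferative activity, read by XTT assay, with a stated time of 24 h (on this read-out lower numbers stand for stronger inhibition and higher numbers for weaker inhibition), so far: compound 1 `Fc1ccc(C2CC(c3ccc(Cl)s3)=NN2c2nc(-c3ccc(Cl)cc3)cs2)cc1` and compound 2 `Cc1ccc(C2=NN(c3nc(-c4ccc(F)cc4)cs3)C(c3ccc(F)cc3)C2)s1`. Compound 1 gives 125 ug/mL and compound 2 gives 125 ug/mL in this test, so compound 2 stands level with compound 1 and the two cannot be ranked. Compound 3 `Cc1ccc(C2=NN(c3nc(-c4ccc(S(C)(=O)=O)cc4)cs3)C(c3ccc(F)cc3)C2)s1` has yet to be measured in this assay and departs from compound 2 in one place, as follows: methylsulfonyl in place of fluoro on an aromatic carbon. In words, methylsulfonyl stands in place of fluoro on an aromatic carbon, which turns 4-fluorophenyl into 4-(methylsulfonyl)phenyl. Within the data shown here, no pair of measured compounds differing in one place is available, so the data offer no direct guide to the size of this change. With compound 2 at 125 ug/mL as the closest reference, no step beyond the scatter is expected in either direction. The estimate therefore means a 1.1-fold lower number from compound 2 to compound 3 (0.06 log units; within the scatter) as the expected step. For compound 3 the estimated value is 110 ug/mL within an expected range of 45 ug/mL to 250 ug/mL for this read-out.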

Compound 3, half-maximal inhibitory concentration: > 500 ug/mL
Compound 3 ended at the assay's limit (the forecaster's own chance of this, stated with the estimate: 15%); at least 4.5-fold (0.65 log units) between middle value and limit.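

In this assay compound 3 gives > 500 ug/mL, which is a limit of the assay and not a number. Methylsulfonyl in place of fluoro on an aromatic carbon, para to a large group, gives an at least 4.0-fold higher number from compound 2 to compound 3 (0.60 log units; beyond the scatter). Among these compounds, this is the only step that can be read so far, and it shows that this position does not accept every group without a loss on this read-out, something compounds 1 and 2 could not show on their own. Its true size remains unknown because the reading for compound 3 is a limit: the limit of > 500 ug/mL in this assay, at which 1 of the 3 values shown sits.

The compounds shown leave open whether the loss is particular to methylsulfonyl or would also follow other groups at this position, such as an amine, a carboxylic acid or a methoxy group. They also leave open whether any group here could give a lower number than compound 2, which stands at 125 ug/mL.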